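The compounds below may be only part of what the source reports. "The series", "measured", "known", "first", "only" and "open" are said of these compounds alone.

Three ureas have been measured in an assay on isolated protein for activation of Nicotinamide phosphoribosyltransferase (Homo sapiens); on this read-out higher numbers stand for an effect only at larger amounts of compound and lower numbers for an effect already at smaller amounts. Compound 1 `CCOC(=O)c1ccc(NC(=O)NCc2cocn2)cc1` gives 27600 nM. Compound 2 `CNS(=O)(=O)c1ccc(NC(=O)NCc2ccncc2)cc1` gives 3230 nM, and compound 3 `O=C(NCc1cn[nH]c1)Nc1ccc(S(=O)(=O)c2ccccc2)cc1` gives 28 nM. Among these three numbers compound 2 stands second highest: the nearest to it is compound 1, whose number is higher by a margin beyond the usual scatter, and the furthest is compound 3, whose number is far lower, again well beyond the scatter.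

The next compound, compound 4 `O=C(NCc1ccncc1)Nc1ccc(S(=O)(=O)c2cccc(Cl)c2)cc1`, has not yet been measured in this assay. It differs from compound 2 in one place: 3-chlorophenyl in place of methylamino on a sulfonyl sulfur. After this change the sulfonyl group carries an aromatic ring on both sides, which is the arrangement found in compound 3.

Among the measured compounds shown here, no directly comparable pair of measured compounds exists for this change, so the expectation rests on compound 3 alone, whose value of 28 nM sits far below that of compound 2. On that basis a large step downward, well beyond the scatter, is expected from compound 2 to compound 4, namely a 54-fold lower number from compound 2 to compound 4 (1.73 log units; beyond the scatter). For compound 4 the estimated value in this assay is 60 nM, with a plausible range from 15 nM to 250 nM.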

Compound 4, half-maximal effective concentration: 69 nM
Compound 4: middle estimate off by 1.2-fold (0.06 log units), on the low side; low and high end bracket the measured number.
By their numbers in this assay, from the lowest: compound 3; then compound 4; then compound 2; then compound 1.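

In this assay, the group on the sulfonyl sulfur turns out to have a strong influence on the result: with the rest of the molecule unchanged, putting 3-chlorophenyl in place of methylamino gives a 47-fold lower number from compound 2 to compound 4 (1.67 log units; beyond the scatter). Among the compounds shown here, this is the first pair differing in only one place, so the size of the effect at this position can now be read directly rather than inferred from compounds that differ in several places at once. The change removes a small group carrying a hydrogen-bond donor and brings in a larger aromatic ring with none, but no measurement here shows which of these differences matters, or why the number falls.

A single step cannot separate the contribution of the ring from that of the chlorine, and a plain phenyl, a cyclohexyl or a dimethylamino group on the same sulfur would help to tell these apart. As far as these compounds go, whether a step of this size would also appear with a different group at the other end of the urea remains open.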